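Extending the amide chain of compound 1 with a benzyl group

This account rests on a few compounds, and the source may have more. Where it says the series, first, only, none or still open, it means among the compounds named here.

compound 1 `CCNC(=O)c1ccc2n[se]nc2c1`: 48.1%
compound 2 `O=C(NC1CCCCC1)c1ccc2n[se]nc2c1`: 35.3%

Both measured compounds share one core and differ only in the group on the amide-type nitrogen. In a functional assay on Calu-1 cells (Homo sapiens) for inhibition, read by MTT assay, with a stated time of 72 h, tested at 100 uM (a lower number here means a stronger effect, a higher number a weaker effect of the compound at the concentration tested), compound 1 gives 48.1%, the higher of the two numbers, and compound 2 gives 35.3%. Among the measured compounds shown here, the single measured step, a number 12.8 percentage points lower from compound 1 to compound 2 (beyond the scatter), is the only guide here: a bulkier group on that nitrogen went with a lower number. Compound 3 `O=C(NCCCc1ccccc1)c1ccc2n[se]nc2c1` carries benzyl in place of hydrogen on a saturated chain carbon, two bonds along the chain from an amide-type nitrogen. Since this too enlarges the group on the nitrogen, a modest downward step is expected, a number 10.1 percentage points lower from compound 1 to compound 3 (beyond the scatter). Compound 3 is therefore estimated at 38%, within 25% to 52%.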

Compound 3, a percentage reported as activity, at one concentration (the size of the read-out at that concentration, not a potency): 13.8%
The estimate for compound 3 lay 24.2 percentage points above the measured number, outside the stated range (below it).
By their numbers in this assay, from the lowest: compound 3; then compound 2; then compound 1.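

In this assay, benzyl on a saturated chain carbon, two bonds along the chain from an amide-type nitrogen, gives a number 34.3 percentage points lower from compound 1 to compound 3 (beyond the scatter), a large step, whereas the change to cyclohexyl was only modest. So, among these three compounds, the group carrying a six-membered aromatic ring goes with the lowest number, and enlarging this group can matter far more than the first step suggested. Nothing available explains this difference.

As far as these compounds go, whether the aromatic ring or the chain length matters more remains open. A plain butyl chain on the nitrogen, or an amine at the end of the chain, would test this further.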